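Amide side-chain variation on the shared core

This account rests on a few compounds, and the source may have more. Where it says the series, first, only, none or still open, it means among the compounds named here.

Compound 1 `COc1cc(CC(C)C(=O)N2CCN(c3ccc(C(F)(F)F)cc3[C@@H](N)CC(C)C)CC2)ccc1Cl` gives 230 nM in an assay on HEK293 cells for displacement of a labelled ligand from Melanocortin receptor 4 (Homo sapiens); a higher number here means a weaker inhibitor, a lower number a stronger inhibitor. Compound 2 `CC(C)C[C@H](N)c1cc(C(F)(F)F)ccc1N1CCN(C(=O)CCC(N)=O)CC1` returns only a limit in this assay, > 10000 nM. Compound 3 `COc1ccc(OCC(=O)N2CCN(c3ccc(C(F)(F)F)cc3[C@@H](N)CC(C)C)CC2)cc1` gives 3800 nM in this assay. Of the two numbers shown, compound 3 stands highest; its nearest neighbour is compound 1, and the step of a 17-fold higher number from compound 1 to compound 3 (1.22 log units; beyond the scatter) is large. The other step away from compound 1 is also large, an at least 43-fold higher number from compound 1 to compound 2 (1.63 log units; beyond the scatter), and between the two amides lacking the benzylic branch the step of an at least 2.6-fold lower number from compound 2 to compound 3 (0.42 log units; beyond the scatter) is at least modest, its size being bounded by the limit of > 10000 nM in this assay, at which 1 of the 3 values shown sits.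

Compound 4 `CC(C)C[C@H](N)c1cc(C(F)(F)F)ccc1N1CCN(C(=O)CSc2ccc(Cl)cc2Cl)CC1` differs from compound 3 in one place: (2,4-dichlorophenyl)sulfanyl in place of 4-methoxyphenoxy on a saturated chain carbon bound to a carbonyl carbon. For the measured compounds named here, the step that bears most directly on it is the one from compound 2 to compound 3, where an aromatic ring on the saturated chain carbon went with a lower number; the step from compound 1 to compound 3 shows how much room lies below compound 3. Going by the values given here, no sulfanyl or dichlorophenyl example is measured here. A modest lowering is expected, well short of compound 1, so for compound 4 the estimate in this assay is 1500 nM, between 300 nM and 6000 nM, meaning the step of a 2.5-fold lower number from compound 3 to compound 4 (0.40 log units; beyond the scatter) is expected.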

Compound 4, inhibition constant: 1500 nM
Beside the measured number, compound 4's estimate shows no gap at the digits printed, and the stated range covers the measured number.
By their numbers in this assay, from the lowest: compound 1; then compound 4; then compound 3. At a limit, above all of these: compound 2.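

In this assay, the change from 4-methoxyphenoxy to (2,4-dichlorophenyl)sulfanyl on a saturated chain carbon bound to a carbonyl carbon gives a modest drop (a 2.5-fold lower number from compound 3 to compound 4 (0.40 log units; beyond the scatter)), so with an aromatic ring kept at this place, the number still moves beyond the scatter when the ring's link and substituents change. Measured against the carbamoylmethyl amide, the drop is wider (an at least 6.6-fold lower number from compound 2 to compound 4 (0.82 log units; beyond the scatter)), but its size is only bounded, as compound 2 stands at a limit: (the limit of > 10000 nM in this assay, at which 1 of the 4 values shown sits). For the compounds shown here, the branched amide of compound 1 remains lower (a 6.5-fold higher number from compound 1 to compound 4 (0.81 log units; beyond the scatter)), and this step is modest where the one to compound 3 was large, so part of the distance to compound 1 can be covered without the 1-(4-chloro-3-methoxybenzyl)ethyl group.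

The link atom and the ring substituents change together here, so the compounds shown do not tell whether the sulfur or the two chlorines go with the lower number; a 2,4-dichlorophenoxy group at this place would separate them. Also open, going by these compounds, is whether a methyl branch on the saturated chain carbon, or a longer chain to the dichlorophenyl ring, would lower the number further.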